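This account rests on a few compounds, and the source may have more. Where it says the series, first, only, none or still open, it means among the compounds named here.

Compound 1 `CCN1CCN(Cc2c(OC)cc(Oc3cccc(Nc4ccccc4)c3)cc2OC)CC1` gives > 20000 nM in a functional assay on SW-620 cells (Homo sapiens) for inhibition, read by MTT assay, with a stated time of 72 h (on this read-out higher numbers stand for weaker inhibition and lower numbers for stronger inhibition), a limit.
Compound 2 `COc1cc(Oc2cccc(Nc3ccccc3)c2)cc(OC)c1CNCc1ccc(Cl)cc1` gives 6340 nM in this assay.
Compound 3 `COc1cc(Oc2cccc(Nc3ccccc3)c2)cc(OC)c1CNC(C)C` gives > 20000 nM in this assay, a limit.

Compound 3 thus stands at the limit of this assay, as does compound 1, while only compound 2 gives a number. Because compound 3 sits at the limit of > 20000 nM in this assay, at which 2 of the 3 values shown sit, the size of any step leaving it cannot be read exactly. Compound 4 `COc1ccc(CNCc2c(OC)cc(Oc3cccc(Nc4ccccc4)c3)cc2OC)cc1` differs from compound 3 by 4-methoxybenzyl in place of isopropyl on an amine nitrogen. The measured step that bears on this is an at least 3.1-fold higher number from compound 2 to compound 3 (0.49 log units; beyond the scatter), the reverse exchange of a benzyl group for isopropyl; the step that the two limits leave unreadable from compound 1 to compound 3 gives no size. Going back from isopropyl to a benzyl group, now 4-methoxybenzyl, is expected to lower the number in this assay by about as much, an expected at least 2.8-fold lower number from compound 3 to compound 4 (0.45 log units; beyond the scatter). Compound 4 is therefore estimated at 7000 nM, with a range of 2500 nM to 20000 nM.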

Compound 4, half-maximal inhibitory concentration: 6970 nM
Compound 4: middle estimate off by 1.0-fold (0.00 log units), on the high side; low and high end bracket the measured number.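

In this assay, 4-methoxybenzyl in place of isopropyl on the amine nitrogen gives an at least 2.8-fold lower number from compound 3 to compound 4 (0.45 log units; beyond the scatter), and (4-methoxybenzyl)amino in place of 4-ethylpiperazin-1-yl gives an at least 2.8-fold lower number from compound 1 to compound 4 (0.45 log units; beyond the scatter). The gain therefore does not depend on the 4-chlorobenzyl group alone: methoxy in place of chloro on an aromatic carbon gives a 1.1-fold higher number from compound 2 to compound 4 (0.04 log units; within the scatter), within the scatter. Both larger steps start from a limit, so their sizes are only lower bounds: the limit of > 20000 nM in this assay, at which 2 of the 4 values shown sit.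

Still open, as far as these compounds go, is whether an unsubstituted benzyl group or a longer chain such as 2-phenylethyl on the amine nitrogen would give a similar number.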